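Swapping a butyl for a pyridin-3-yl on the amide nitrogen

The source may report more compounds than this note shows. Statements on the series, on what has been measured and on what is new or still open speak of the compounds shown alone.

Measured so far:
compound 1, `O=C(Nc1ccccn1)c1c(O)c2cccnc2n(-c2ccccc2)c1=O`: 14.6%
compound 2, `CCCCNC(=O)c1c(O)c2cccnc2n(-c2ccccc2)c1=O`: 20.4%
compound 3, `Cc1ccccc1NC(=O)c1c(O)c2cccnc2n(-c2ccccc2)c1=O`: 9.8%

In a functional assay on the whole organism for inhibition, with Rattus norvegicus as the target, read by cytopathic effect and paw edema, at a dose of 100 mg/kg by the oral route (a lower number here means less inhibition, a higher number more inhibition at the dose given (going by the name of the read-out)), compound 2 stands highest of the three numbers, though its lead over compound 1 is within the scatter. Compound 4, `O=C(Nc1cccnc1)c1c(O)c2cccnc2n(-c2ccccc2)c1=O`, differs from compound 2 in one place: pyridin-3-yl in place of butyl on an amide-type nitrogen. For the measured compounds named here, two measured steps bear on this change. Replacing butyl with a ring gave a number 10.6 percentage points lower from compound 2 to compound 3 (beyond the scatter), while the reverse change, a ring to butyl, gave a number 5.8 percentage points higher from compound 1 to compound 2 (within the scatter). Both point the same way, so compound 4 is expected to sit somewhat lower than compound 2, most likely a drop that stays within the scatter, a number 6.4 percentage points lower from compound 2 to compound 4 (within the scatter). Compound 4 is therefore estimated at 14%, within a range from 5% to 24%.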

Compound 4, a percentage reported as inhibition, in the whole organism at one dose (the size of the read-out at that dose, not a potency): 30.8%
Compound 4: the middle estimate sits 16.8 percentage points below what was measured; measured number above the stated range.
By their numbers in this assay, from the lowest: compounds 3, 1 and 2 (each within the scatter of the next, the first and the last beyond it); then compound 4.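

In this assay a ring on the amide-type nitrogen need not lower the number, since pyridin-3-yl in place of butyl gives a number 10.4 percentage points higher from compound 2 to compound 4 (beyond the scatter), although 2-methylphenyl had sat lower than butyl. The identity of the ring counts here: pyridin-3-yl in place of 2-methylphenyl gives a number 21 percentage points higher from compound 3 to compound 4 (beyond the scatter), and pyridin-3-yl in place of pyridin-2-yl gives a number 16.2 percentage points higher from compound 1 to compound 4 (beyond the scatter). No measurement shown explains this rise.

Still open, as far as these compounds go, is how pyridin-4-yl, unsubstituted phenyl or a longer chain on this nitrogen would compare with pyridin-3-yl. Also open, from the compounds shown here alone, is how these compounds would rank at other oral doses.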